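Bromo to Chloro on the Aryl Ketone Ring

A few compounds are considered here, and "the series" means these few. Any claim that something is new, unique, unknown or untested is made for them only; others in the source may bear on it.

compound 1 `COC(=O)c1cc(-c2cccc(NC(=O)c3ccc(/C=C/C(=O)c4ccccc4)cc3)c2)on1`: in an ADME assay on Vero cells (Chlorocebus sabaeus) for cytotoxicity, read by MTT assay, with a stated time of 72 h (on this read-out higher numbers stand for lower toxicity in this test and lower numbers for higher toxicity in this test), compound 1 gives > 50 ug/mL, a limit of the assay.
compound 2 `COC(=O)c1cc(-c2cccc(NC(=O)c3ccc(/C=C/C(=O)c4ccc(C)c(F)c4)cc3)c2)on1`: in this assay compound 2 gives > 50 ug/mL, a limit of the assay.
compound 3 `COC(=O)c1cc(-c2cccc(NC(=O)c3ccc(/C=C/C(=O)c4ccc(Br)cc4)cc3)c2)on1`: in this assay compound 3 gives > 20 ug/mL, a limit of the assay.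

Compound 3 stands nowhere that can be ranked: its own result in this assay is a limit and not a number, and the two further results shown are limits as well. The three steps among the measured compounds are therefore all unreadable: a step that the two limits leave unreadable from compound 1 to compound 2, a step that the two limits leave unreadable from compound 1 to compound 3 and a step that the two limits leave unreadable from compound 2 to compound 3. What the set does show is the limit of > 20 ug/mL in this assay, at which 1 of the 3 values shown sits, and (the limit of > 50 ug/mL in this assay, at which 2 of the 3 values shown sit), so none of the three compounds reached a measurable toxicity within the tested window.

Compound 4 `COC(=O)c1cc(-c2cccc(NC(=O)c3ccc(/C=C/C(=O)c4ccc(Cl)cc4)cc3)c2)on1` differs from compound 3 by chloro in place of bromo on an aromatic carbon. For the measured compounds named here, no measured step covers this exchange, and the halogen steps that exist leave no readable size. With every value a limit, no direction can be read, and the halogen exchange gives no ground to expect a step beyond the scatter.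

Compound 4 is therefore expected to sit again at a limit, estimated at 60 ug/mL with a range from 25 ug/mL to 150 ug/mL. The estimated step that the limit leaves unreadable from compound 3 to compound 4 is expected to be none beyond the scatter.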

Compound 4, half-maximal cytotoxic concentration: > 50 ug/mL
Compound 4 ended at the assay's limit; the forecaster's own chance of this, stated with the estimate: 80%; the middle value is on the limit's open side.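

In this assay compound 4 gives > 50 ug/mL, a limit of the assay. For the compounds shown here, no step between compound 4 and compound 1, compound 2 or compound 3 can be read, as all four values shown are limits. The compounds shown leave open at what concentration any of them becomes toxic in this assay, and whether chloro and bromo differ there at all.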